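Removing the bromo group: expected effect on cytotoxicity

The source may hold more compounds than are shown below. What is called first, only, known or untested is meant among the compounds shown, and "the series" means these compounds.

For the measured compounds named here, the series so far holds two measured compounds sharing one core. Compound 1 `COc1ccc(-n2cc(-c3ccccc3)c(-c3ccc4c(c3)NC(=O)CO4)n2)cc1` carries a methoxy group on the outer aromatic ring; in a functional assay on MV4-11 cells (Homo sapiens) for cytotoxicity, read by colorimetric assay and MTT assay, with a stated time of 3 days, tested at 1 uM (on this read-out higher numbers stand for a weaker effect at the one concentration tested and lower numbers for a stronger effect), compound 1 gives 106%. Compound 2 `O=C1COc2ccc(-c3nn(-c4ccc(Br)cc4)cc3-c3ccccc3)cc2N1` carries bromo at the same position; in this assay compound 2 gives 108%. The two numbers sit within the scatter of one another, and both lie at the top of the range, so neither compound shows a clear effect at the tested concentration. Going by the values given here, the single measured step, a number 2 percentage points higher from compound 1 to compound 2 (within the scatter), is the only one that touches the position in question.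

Compound 3 `O=C1COc2ccc(-c3nn(-c4ccccc4)cc3-c3ccccc3)cc2N1` is the next member, differing from compound 2 by hydrogen in place of bromo on an aromatic carbon. Among the compounds with values here, the one relevant precedent, the exchange of methoxy for bromo at this position, moved the read-out by an amount within the scatter, which gives no reason to expect a different outcome when the bromo is removed altogether. The expected step in this assay from compound 2 to compound 3 is therefore a number 2 percentage points lower from compound 2 to compound 3 (within the scatter), i.e. none beyond the scatter. Compound 3 is accordingly estimated to give 106% in this assay, within a range from 96% to 116%.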

Compound 3, a percentage reported as activity, at one concentration (the size of the read-out at that concentration, not a potency): 117%
Compound 3: the middle estimate sits 11 percentage points below what was measured; the measured number lies above the stated range.
By their numbers in this assay, from the lowest: compounds 1, 2 and 3 (each within the scatter of the next, the first and the last beyond it).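

Dropping the substituent gives the first step at this position that stands clear of the scatter: in this assay, a number 11 percentage points higher from compound 1 to compound 3 (beyond the scatter), a modest shift toward a weaker effect for hydrogen in place of methoxy. The change from 4-bromophenyl to phenyl stays unresolved, with a number 9 percentage points higher from compound 2 to compound 3 (within the scatter), so the phenyl compound separates from the methoxy compound but not from the bromo compound, and the three do not split cleanly into substituted and unsubstituted. Nothing available explains the methoxy-to-hydrogen step, and no measurement bears on it.

For the compounds shown here, none of the three substituents on this ring, para to a large group, gives a stronger effect at the one concentration tested, and the only step beyond the scatter is modest and rests on a single pair. It remains open whether an amine, a carboxylic acid or a longer alkoxy chain at this position would bring the number down at all, and whether any difference among these compounds would appear at other concentrations.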